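This account rests on a few compounds, and the source may have more. Where it says the series, first, only, none or still open, it means among the compounds named here.

Measured compounds:
Compound 1, `O=C1/C(=C\c2cccc(Oc3ccccc3)c2)c2ccccc2N1c1c(Cl)cccc1Cl`, gives 6 ug/mL in a functional assay on MOLT-4 cells (Homo sapiens) for cytotoxicity, read by MTT assay, with a stated time of 72 h; a lower number here means that less compound is needed, a higher number that more compound is needed for the effect.
Compound 2, `O=C1/C(=C\c2ccc(F)cc2)c2ccccc2N1c1c(Cl)cccc1Cl`, has "not determined" (no result reported) in this assay.
Compound 3, `O=C1/C(=C\c2ccccc2Cl)c2ccccc2N1c1c(Cl)cccc1Cl`, gives 7 ug/mL in this assay.

Compound 2 therefore stands without a number in this assay: it was not determined, so nothing can be said of where it lies against compound 1 or compound 3. The two compounds that do carry values, compound 1 and compound 3, lie within the usual scatter of each other, so neither is placed above the other.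

Compound 4, `O=C1/C(=C\c2cccc(Cl)c2)c2ccccc2N1c1c(Cl)cccc1Cl`, is the next compound in this series. Its structure differs from compound 2 in one place: 3-chlorophenyl in place of 4-fluorophenyl on a double-bonded chain carbon bound to a double-bonded ring carbon. Among the measured compounds shown here, since compound 2 has no measured value, no step from compound 2 to compound 4 can be sized or given a direction in this assay; the expectation for compound 4 rests only on compound 1 and compound 3.

Compound 4 is expected to give about 7 ug/mL in this assay, in line with the values of compound 1 and compound 3. The estimated range for compound 4 runs from 3 ug/mL to 16 ug/mL.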

Compound 4, concentration for half-maximal effect: 6 ug/mL
The estimate for compound 4 lay 1.2-fold (0.07 log units) above the measured number; the range from low to high includes it.
By their numbers in this assay, from the lowest: compounds 1, 4 and 3 (each within the scatter of the next).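

In this assay, the change from 2-chlorophenyl to 3-chlorophenyl gives a 1.2-fold lower number from compound 3 to compound 4 (0.07 log units; within the scatter) and stays within the scatter, so these two chlorophenyl groups are not told apart at this position. Chloro in place of phenoxy on an aromatic carbon gives no change at the digits printed from compound 1 to compound 4 (within the scatter) and also stays within the scatter, so the read-out separates neither the two chlorophenyl groups nor chloro and phenoxy. Nothing at hand bears on why these numbers stay so close.

Steps involving compound 2 cannot be read, so the 4-fluorophenyl group remains unplaced against the others. As far as these compounds go, it also remains open whether an amine or a carboxylic acid on that aromatic carbon would move the number beyond the scatter.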